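The source may hold more compounds than are shown below. What is called first, only, known or untested is meant among the compounds shown, and "the series" means these compounds.

In an ADME assay on HepG2 cells (Homo sapiens) for cytotoxicity, read by MTT assay, with a stated time of 72 h (a higher number here means that more compound is tolerated, a lower number that less compound is tolerated), compound 2 (`O=[N+]([O-])c1c(CS(=O)(=O)c2ccccc2)nc2c(-c3cccnc3)cc(Cl)cn12`) gives > 31300 nM as a limit of the assay and not a number. Compound 1 (`N#Cc1ccc(-c2cc(Cl)cn3c([N+](=O)[O-])c(CS(=O)(=O)c4ccccc4)nc23)cc1`) likewise gives > 3900 nM as a limit. Going by the values given here, the only measured step is therefore a step that the two limits leave unreadable from compound 1 to compound 2 and it offers no size to carry forward. Compound 3 (`O=[N+]([O-])c1c(CS(=O)(=O)c2ccccc2)nc2c(-c3cccs3)cc(Cl)cn12`) keeps the shared core of compound 2 and changes one group: thiophen-2-yl in place of pyridin-3-yl on an aromatic carbon. Among the compounds with values here, no measured step covers this swap, and neither measured compound has yet given a true number. A large shift in this assay is thus not expected, though any readable value would have to lie on the lower side of the limit of compound 2. The expected change is an at least 1.4-fold lower number from compound 2 to compound 3 (0.15 log units; that floor lies within the scatter) (an estimate). The estimate for compound 3 is 22000 nM (expected range 6000 nM to 60000 nM).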

Compound 3, half-maximal cytotoxic concentration: > 3900 nM
Compound 3 was reported as a limit; the forecaster's own chance of this, stated with the estimate: 60%; the middle value is on the limit's open side.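

Compound 1, compound 2 and compound 3 are all reported as limits of the assay and not as numbers, so the steps among them cannot be read. As far as these compounds go, what stays open is where the half-maximal cytotoxic concentration of each compound truly lies, and whether swapping the group on the aromatic carbon changes it at all.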